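The compounds below may be only part of what the source reports. "The series", "measured", "known", "first", "only" and "open" are said of these compounds alone.

In a functional assay on CHO-K1 cells for antagonist activity at transient receptor potential cation channel subfamily V member 1 (Homo sapiens), read by FLIPR (a lower number here means a stronger inhibitor, a higher number a weaker inhibitor), compound 3 `CC(C(=O)NCc1ccc(C(F)(F)F)nc1N1CCN(c2ncccc2Cl)CC1)c1ccc(NS(C)(=O)=O)c(F)c1` gives 2.1 nM, the smallest of the three numbers, although its gaps to the others lie within the scatter: compound 2 `COc1ccc(N2CCN(c3nc(C(F)(F)F)ccc3CNC(=O)C(C)c3ccc(NS(C)(=O)=O)c(F)c3)CC2)cc1` gives 2.5 nM and compound 1 `Cc1cccc(N2CCN(c3nc(C(F)(F)F)ccc3CNC(=O)C(C)c3ccc(NS(C)(=O)=O)c(F)c3)CC2)c1` gives 3.4 nM, with a 1.6-fold lower number from compound 1 to compound 3 (0.21 log units; within the scatter), a 1.2-fold lower number from compound 2 to compound 3 (0.08 log units; within the scatter) and a 1.4-fold lower number from compound 1 to compound 2 (0.13 log units; within the scatter). Compound 4 `CC(C(=O)NCc1ccc(C(F)(F)F)nc1N1CCN(c2ncccc2Cl)CC1C)c1ccc(NS(C)(=O)=O)c(F)c1` differs from compound 3 by methyl in place of hydrogen on a saturated ring carbon. For the measured compounds named here, all measured steps exchange only the group on the ring nitrogen, so no step directly bears on this change; those steps were all small and within the scatter. He therefore expects no step beyond the scatter in this assay, a 1.9-fold higher number from compound 3 to compound 4 (0.28 log units; within the scatter), and estimates compound 4 at 4 nM, between 1.5 nM and 12 nM.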

Compound 4, inhibition constant: 4.1 nM
For compound 4 the middle estimate is 1.0-fold (0.01 log units) below the measured one; measured number inside the range.
By their numbers in this assay, from the lowest: compounds 3, 2, 1 and 4 (each within the scatter of the next).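

The earlier compounds shown here exchanged only the group on the ring nitrogen, whereas here the saturated ring itself changes: in this assay, methyl in place of hydrogen on a saturated ring carbon, next to the ring nitrogen, gives a step that stays within the scatter (a 2.0-fold higher number from compound 3 to compound 4 (0.29 log units; within the scatter)). This position therefore takes the added methyl without a step beyond the scatter. No evidence here speaks to the reason for this result.

The compounds shown leave open how ethyl or hydroxymethyl would read at this carbon. They also leave open whether the same methyl behaves alike with 3-methylphenyl or 4-methoxyphenyl on the ring nitrogen.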